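The source may hold more compounds than are shown below. What is called first, only, known or untested is meant among the compounds shown, and "the series" means these compounds.

Measured in a functional assay (brain) with Rattus norvegicus as the target; on this read-out lower numbers stand for stronger inhibition and higher numbers for weaker inhibition:
- compound 1 `COC(=O)[C@H]1CN(C)CC[C@@H]1c1ccc2ccccc2c1`: > 1000 nM, a limit and not a number
- compound 2 `COC(=O)[C@H]1CN(C)CC[C@H]1c1ccc2ccccc2c1`: 293 nM
- compound 3 `C=Cc1ccc([C@H]2CCN(C)C[C@H]2C(=O)OC)cc1`: 144 nM

Of the two true numbers, compound 3 holds the lower one, against compound 2 at 293 nM. Compound 4 `COC(=O)[C@@H]1CN(C)CC[C@@H]1c1ccc(-c2ccccc2)cc1` carries phenyl in place of vinyl on an aromatic carbon, para to a large group: phenyl in place of vinyl on an aromatic carbon. Within the data shown here, the only measured step is an at least 3.4-fold lower number from compound 1 to compound 2 (0.53 log units; beyond the scatter). It reflects the fact that compounds 1 and 2 differ only in the configuration as drawn and is bounded by the limit of > 1000 nM in this assay, at which 1 of the 3 values shown sits, so it bears only indirectly on this exchange. A modest move to a higher number in this assay is expected, resting on compound 2 at 293 nM, which has a larger aromatic group. The expected step is a 3.5-fold higher number from compound 3 to compound 4 (0.54 log units; beyond the scatter). The estimate for compound 4 is 500 nM, with an expected range of 130 nM to 2000 nM.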

Compound 4, half-maximal inhibitory concentration: 184 nM
The estimate for compound 4 lay 2.7-fold (0.43 log units) above the measured number; low and high end bracket the measured number.
By their numbers in this assay, from the lowest: compounds 3, 4 and 2 (each within the scatter of the next, the first and the last beyond it). At a limit, above all of these: compound 1.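

In this assay, phenyl in place of vinyl on an aromatic carbon, para to a large group, gives a 1.3-fold higher number from compound 3 to compound 4 (0.11 log units; within the scatter) and so leaves the read-out unseparated. Among these compounds, this position thus takes a six-membered aromatic ring of 6 heavy atoms as well as a ring-free group of 2 heavy atoms, which no earlier step could show. No available evidence bears on this exchange.

Going by these compounds, whether an amine or a carboxylic acid on this aromatic carbon would fit the same pattern stays open. So does the outcome for a longer carbon chain there.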